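This account rests on a few compounds, and the source may have more. Where it says the series, first, only, none or still open, it means among the compounds named here.

Series notes. Compound 1 `O=C1NC(=O)/C(=C/c2ccc(OCCSc3nnc(-c4ccccc4)[nH]3)cc2)S1` gives 14.7% in a functional assay on the whole organism (plasma, strain Wistar) with Rattus norvegicus as the target, with a stated time of 15 days, at a dose of 30 mg/kg by the oral route; on this read-out lower numbers stand for a weaker effect and higher numbers for a stronger effect at the one dose given. Compound 2 `O=C1NC(=O)/C(=C/c2ccc(OCCSc3nnc(-c4ccc(Cl)cc4)[nH]3)cc2)S1` gives 23.7% in this assay. On the numbers shown compound 2 stands nearest to compound 1, and the only measured step, a number 9 percentage points higher from compound 1 to compound 2 (within the scatter), lies within the scatter, so the two values are not distinguishable; this step brought chloro in place of hydrogen on an aromatic carbon. Compound 3 `O=C1NC(=O)/C(=C/c2ccc(OCCSc3nnc(-c4ccc(Br)cc4)[nH]3)cc2)S1` is not yet measured in this assay. It differs from compound 2 by bromo in place of chloro on an aromatic carbon. Among the measured compounds shown here, no measured step involves a bromo group, and the one step that bears on this position was itself within the scatter. The step from compound 2 to compound 3 is therefore expected to be a number 1.3 percentage points higher from compound 2 to compound 3 (within the scatter), that is, none beyond the scatter. For compound 3 the estimate in this assay is 25%, with an expected range from 10% to 40%.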

Compound 3, a percentage reported as activity, at one dose (the size of the read-out at that dose, not a potency): 19.5%
Compound 3: the middle estimate sits 5.5 percentage points above what was measured; the measured number falls inside the stated range.
By their numbers in this assay, from the lowest: compounds 1, 3 and 2 (each within the scatter of the next).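

In this assay the change from 4-chlorophenyl to 4-bromophenyl gives a number 4.2 percentage points lower from compound 2 to compound 3 (within the scatter) and so does not separate the two halogens at this place. Measured against the unsubstituted parent, bromo gives a number 4.8 percentage points higher from compound 1 to compound 3 (within the scatter) and so, like chloro, does not separate from hydrogen on this aromatic carbon, para to a large group; the three compounds therefore cannot be ordered on this read-out. Nothing available bears on the reason for this result.

On these data alone, whether any group at this place can move the read-out beyond the scatter stays open, for instance a methoxy group, an amine or a carboxylic acid. Also open, as far as these compounds go, is how the read-out responds to changes elsewhere, such as a longer chain in the linker of the shared core.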